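Methyl on the piperidine: compound 2 to compound 3

The source may report more compounds than this note shows. Statements on the series, on what has been measured and on what is new or still open speak of the compounds shown alone.

Compound 1 `COc1cc2c(Nc3nc4ccc(C(=O)Nc5c(C)cccc5C)cc4s3)ncnc2cc1OCCCN1CCC(C)CC1`: 89700 nM
Compound 2 `COc1cc2c(Nc3nc4ccc(C(=O)Nc5c(C)cccc5Cl)cc4s3)ncnc2cc1OCCCN1CCCCC1`: 12800 nM

In a functional assay on A549 cells (Homo sapiens) for cytotoxicity, read by WST assay, with a stated time of 72 h (a higher number here means a weaker inhibitor, a lower number a stronger inhibitor), compound 2 gives 12800 nM, the lower of the two numbers; compound 1 gives 89700 nM, a higher number that lies beyond the scatter. Compound 3 `COc1cc2c(Nc3nc4ccc(C(=O)Nc5c(C)cccc5Cl)cc4s3)ncnc2cc1OCCCN1CCC(C)CC1` differs from compound 2 by methyl in place of hydrogen on a saturated ring carbon. Going by the values given here, no pair of measured compounds differs by this change alone, so its effect cannot be read from the data. The step of a 1.3-fold higher number from compound 2 to compound 3 (0.10 log units; within the scatter) is expected to stay within the scatter. Compound 3 is estimated at 16000 nM, between 5000 nM and 50000 nM.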

Compound 3, half-maximal inhibitory concentration: 9700 nM
Estimate against measurement, compound 3: 1.6-fold (0.22 log units) above; low and high end bracket the measured number.
By their numbers in this assay, from the lowest: compounds 3 and 2 (each within the scatter of the next); then compound 1.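

In this assay, 4-methylpiperidin-1-yl in place of piperidin-1-yl leaves the number within the scatter, with a 1.3-fold lower number from compound 2 to compound 3 (0.12 log units; within the scatter) on this saturated ring carbon. With that methyl present in both compounds, chloro in place of methyl on an aromatic carbon gives a 9.2-fold lower number from compound 1 to compound 3 (0.97 log units; beyond the scatter) and stands beyond the scatter. The large gap between compound 1 and compound 2 therefore follows the aromatic change, not the ring methyl. On these data alone, whether a hydroxyl, an amine or a phenyl at this ring carbon would stay within the scatter remains open. Nothing measured here explains either step.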